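Replacing the 4-methoxyphenyl group of compound 2

The source may report more compounds than this note shows. Statements on the series, on what has been measured and on what is new or still open speak of the compounds shown alone.

In a functional assay on MDA-MB-436 cells (Homo sapiens) for antiproliferative activity, read by MTT assay, with a stated time of 48 h (a lower number here means a stronger inhibitor, a higher number a weaker inhibitor), compound 1 (`C=CS(=O)(=O)N1CCN(c2ncnc3sc(-c4ccc(N5CCN(C)CC5)cc4)cc23)CC1`) gives 8760 nM and compound 2 (`COc1ccc(NC(=O)N2CCN(c3ncnc4sc(-c5ccc(N6CCN(C)CC6)cc5)cc34)CC2)cc1`) gives 30100 nM as the higher of the two numbers, so compound 2 is the weaker of this pair. Compound 3 (`CN1CCN(c2ccc(-c3cc4c(N5CCN(C(=O)Nc6ccc(F)cc6F)CC5)ncnc4s3)cc2)CC1`) differs from compound 2 in one place (2,4-difluorophenyl in place of 4-methoxyphenyl on an amide-type nitrogen): 2,4-difluorophenyl in place of 4-methoxyphenyl on an amide-type nitrogen. Within the data shown here, the only measured step is a 3.4-fold higher number from compound 1 to compound 2 (0.54 log units; beyond the scatter) and it is modest, but it exchanged vinylsulfonyl for the whole (4-methoxyphenyl)carbamoyl, whereas here the carbamoyl stays. That step therefore offers only a rough guide to size, and no step beyond the scatter is expected in this assay, with a slight lean towards a lower number. The expected move is a 1.4-fold lower number from compound 2 to compound 3 (0.14 log units; within the scatter) and this is only an estimate. For compound 3 the expected value is 22000 nM within an estimated range from 9000 nM to 50000 nM for repeated measurements.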

Compound 3, half-maximal inhibitory concentration: 20200 nM
For compound 3 the middle estimate is 1.1-fold (0.04 log units) above the measured one, within the range that was stated.
By their numbers in this assay, from the lowest: compound 1; then compounds 3 and 2 (each within the scatter of the next).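

In this assay, 2,4-difluorophenyl in place of 4-methoxyphenyl on the amide-type nitrogen gives a 1.5-fold lower number from compound 2 to compound 3 (0.17 log units; within the scatter), so this exchange, the first shown that keeps the carbamoyl, does not separate the two compounds. The other step, a 2.3-fold higher number from compound 1 to compound 3 (0.36 log units; beyond the scatter), shows that vinylsulfonyl also stands apart from the carbamoyl with this second ring, and the gap remains modest in size. Nothing measured here explains these numbers.

As far as these compounds go, whether a cyclohexyl group or a pyridine ring on that nitrogen would move the number beyond the scatter remains open. Also open, from the compounds shown here alone, is whether an acrylamide in place of vinylsulfonyl would give a number closer to that of compound 1 or to those of the carbamoyl compounds.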